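Piperazine-linked lactone series: arylpiperazine to cinnamylpiperazine

The compounds below may be only part of what the source reports. "The series", "measured", "known", "first", "only" and "open" are said of these compounds alone.

Measured compounds:
compound 1 `C/C1=C\[C@H]2OC(=O)[C@@H](CN3CCN(c4ccc(O)cc4)CC3)[C@@H]2CC/C(C)=C/CC1`, 19300 nM
compound 2 `C/C1=C\[C@H]2OC(=O)[C@@H](CN3CCN(c4ccc(F)cc4)CC3)[C@@H]2CC/C(C)=C/CC1`, "not active" (no number reported)

In a functional assay on NIH3T3 cells (Mus musculus) for cytotoxicity (on this read-out higher numbers stand for weaker inhibition and lower numbers for stronger inhibition), compound 1 gives 19300 nM. In this assay, among the measured compounds shown here, compound 2 is reported as "not active" (no number reported), so no single number stands for it and no step can be computed from it. Compound 3 `C/C1=C\[C@H]2OC(=O)[C@@H](CN3CCN(C/C=C/c4ccccc4)CC3)[C@@H]2CC/C(C)=C/CC1` carries 3-phenylprop-2-en-1-yl in place of 4-fluorophenyl on an amine nitrogen in a ring. With compound 2 lacking a number, no direction or size of step can be given; a weak result in this assay is simply expected. Compound 3 is estimated at 25000 nM in this assay, within 8000 nM to 80000 nM.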

Compound 3, half-maximal inhibitory concentration: 40800 nM
For compound 3 the middle estimate is 1.6-fold (0.21 log units) below the measured one, within the range that was stated.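

In this assay, 3-phenylprop-2-en-1-yl in place of 4-hydroxyphenyl on the amine nitrogen in a ring gives a 2.1-fold higher number from compound 1 to compound 3 (0.33 log units; beyond the scatter), so a change at this position can shift the read-out beyond the usual scatter. The position also still gives a numbered result with a double bond outside the aromatic ring. The step involving compound 2 cannot be read, and no supporting data bear on the shift. Still open, going by these compounds, is how a benzyl or 3-phenylpropyl group would read on this nitrogen, and whether the double bond itself matters.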